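The source may hold more compounds than are shown below. What is called first, only, known or untested is meant among the compounds shown, and "the series" means these compounds.

In a functional assay on KG-1 cells (Homo sapiens) for cytotoxicity, read by luminescence and CellTiter-Glo, with a stated time of 3 days (on this read-out higher numbers stand for weaker inhibition and lower numbers for stronger inhibition), compound 1 `N#Cc1ccc(NC(=O)c2cc(-c3ccncc3)ccc2O)cc1` gives 7990 nM. Compound 2 `N#Cc1cccc(NC(=O)c2cc(F)ccc2O)c1` gives 9100 nM, which lies within the scatter of the number for compound 1. Compound 3 `N#Cc1ccc(NC(=O)c2ccc3ccccc3c2)cc1` reads > 10000 nM, and this is a limit of the assay, not a number. Within the data shown here, compound 1 therefore stands level with compound 2, and these are the only two numbers available. Compound 4 `Cc1ccc(O)c(C(=O)Nc2ccc(C#N)cc2)c1` follows from compound 1 by one change: methyl in place of pyridin-4-yl on an aromatic carbon. Among the measured compounds shown here, no measured step covers this change, so no shift beyond the scatter is expected in this assay. The estimated step runs a 1.1-fold higher number from compound 1 to compound 4 (0.05 log units; within the scatter). For compound 4 the expected value is 9000 nM, with an estimated range of 4000 nM to 20000 nM.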

Compound 4, half-maximal inhibitory concentration: 3370 nM
Compound 4: middle estimate off by 2.7-fold (0.43 log units), on the high side; measured number below the stated range.
By their numbers in this assay, from the lowest: compound 4; then compounds 1 and 2 (each within the scatter of the next). At a limit, above all of these: compound 3.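

Replacing pyridin-4-yl with methyl gives a 2.4-fold lower number from compound 1 to compound 4 (0.37 log units; beyond the scatter) in this assay, so the group on this aromatic carbon, para to a hydroxy group, does change the read-out. The six-membered aromatic ring is therefore not required at this position for the activity of compound 4. Nothing measured here gives a cause for this step.

The compounds shown leave open whether an ethyl group, a methoxy group or an amine at this carbon would lower the number further. They also leave open whether a phenyl ring would read like pyridin-4-yl or like methyl.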